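Anilino-purine hydroxamate-free series: single-concentration antiproliferative notes

The source may hold more compounds than are shown below. What is called first, only, known or untested is meant among the compounds shown, and "the series" means these compounds.

Measured compounds:
compound 1 `CC(C)n1cnc2c(Nc3cccc(Cl)c3)nc(NCOCc3ccc(C(=O)Nc4ccccc4N)cc3)nc21`: 63.4%
compound 2 `Nc1ccccc1NC(=O)/C=C/c1ccc(Cn2cnc3c(Nc4cccc(Cl)c4)nc(Cl)nc32)cc1`: 15.8%

In a functional assay on HCT-116 cells (Homo sapiens) for antiproliferative activity, read by CCK-8 assay, with a stated time of 72 h, tested at 8 uM (on this read-out lower numbers stand for a weaker effect and higher numbers for a stronger effect at the one concentration tested), compound 1 gives 63.4%. In this assay compound 2 gives 15.8%, the lowest of the two numbers; the gap to compound 1 lies beyond the scatter. For the measured compounds named here, compound 1 and compound 2 differ in several places at once, so no single step between them can be read.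

Compound 3 `Cc1ccc(Nc2nc(Cl)nc3c2ncn3Cc2ccc(/C=C/C(=O)Nc3ccccc3N)cc2)cc1` is the next compound to be measured in this assay. It keeps the whole of compound 2 except for one change: 4-methylphenyl in place of 3-chlorophenyl on a nitrogen on an aromatic ring. Going by the values given here, no measured pair shows this exchange, so there is nothing to anchor its size or direction. The expectation is a step from compound 2 to compound 3 of a number 2.2 percentage points higher from compound 2 to compound 3 (within the scatter), not clearly beyond the scatter. Compound 3 is therefore estimated at 18%, within 5% to 40%.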

Compound 3, a percentage reported as inhibition, at one concentration (the size of the read-out at that concentration, not a potency): 15%
Compound 3: the middle estimate sits 3 percentage points above what was measured; the range from low to high includes it.
By their numbers in this assay, from the lowest: compounds 3 and 2 (each within the scatter of the next); then compound 1.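

For the compounds shown here, with only this one step to read at this position, in this assay 4-methylphenyl in place of 3-chlorophenyl on a nitrogen on an aromatic ring gives a number 0.8 percentage points lower from compound 2 to compound 3 (within the scatter). On this read-out the two groups cannot be told apart, so the 3-chlorophenyl of compound 2 holds no distinction here against the 4-methylphenyl of compound 3. The two names differ in both the substituent and where it sits on the ring, and this single step cannot separate those two differences; no measurement on hand offers a reason for the two compounds reading alike.

Steps to compound 1 cannot be read, as it differs from both in several places. Open, going by these compounds, are an unsubstituted phenyl, a cyclohexyl or a ring carrying a carboxylic acid on that nitrogen, and whether this exchange reads the same on the core of compound 1.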